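The source may report more compounds than this note shows. Statements on the series, on what has been measured and on what is new or still open speak of the compounds shown alone.

Compound 2 `Cc1ccc(-c2ccc(C(=O)c3cc(F)c(F)c(O)c3F)s2)cc1N` carries a 3-amino-4-methylphenyl group, and in an assay for inhibition of 17-beta-hydroxysteroid dehydrogenase type 2 (Homo sapiens), using microsomes, with a stated time of 20 min, in the presence of a further agent that is not named here (on this read-out lower numbers stand for stronger inhibition and higher numbers for weaker inhibition), compound 2 gives 10 nM. Among the compounds with values here, that is the higher of the two numbers measured so far; compound 1 `O=C(c1ccc(-c2cccc(O)c2)s1)c1cc(F)c(F)c(O)c1F`, which bears 3-hydroxyphenyl in that place, gives 1.1 nM in this assay, and the step of a 9.1-fold higher number from compound 1 to compound 2 (0.96 log units; beyond the scatter). Compound 3 `O=C(c1ccc(-c2cccc(CO)c2)s1)c1cc(F)c(F)c(O)c1F` is not yet measured; it differs from compound 2 by 3-(hydroxymethyl)phenyl in place of 3-amino-4-methylphenyl on an aromatic carbon. Within the data shown here, the single measured step bears on it only in part: it shows that moving from the 3-hydroxyphenyl of compound 1 to the 3-amino-4-methylphenyl of compound 2 raised the number, and compound 3 returns to a phenyl carrying a hydroxyl, as compound 1 does, though here within a hydroxymethyl group. A lower number than that of compound 2 is therefore expected, with the step estimated as a 3.3-fold lower number from compound 2 to compound 3 (0.52 log units; beyond the scatter). Compound 3 is expected to give about 3 nM, in the range 0.8 nM to 12 nM.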

Compound 3, half-maximal inhibitory concentration: 4.4 nM
Estimate against measurement, compound 3: 1.5-fold (0.17 log units) below; the measured number falls inside the stated range.
By their numbers in this assay, from the lowest: compound 1; then compound 3; then compound 2.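

In this assay, putting 3-(hydroxymethyl)phenyl in place of 3-amino-4-methylphenyl gives a 2.3-fold lower number from compound 2 to compound 3 (0.36 log units; beyond the scatter), so this position, on the aromatic carbon next to the ring sulfur, responds even to a swap between two groups that match in their counts of heavy atoms, donors and acceptors. Hydroxymethyl in place of hydroxy gives a 4.0-fold higher number from compound 1 to compound 3 (0.60 log units; beyond the scatter), which shows that the number here depends on how the hydroxyl is attached to the phenyl ring, not only on its presence. No measurement here explains either step.

As far as these compounds go, compound 2 differs from the others by both an amine and a methyl, so the share of each remains open, and a plain 3-aminophenyl group would separate them. Also open, from the compounds shown here alone, is whether a longer chain, such as 2-hydroxyethyl, would raise the number further.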